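This account rests on a few compounds, and the source may have more. Where it says the series, first, only, none or still open, it means among the compounds named here.

Values in a functional assay on LoVo cells (Homo sapiens) for inhibition, read by MTT assay, with a stated time of 48 h; a lower number here means a stronger inhibitor, a higher number a weaker inhibitor:
compound 1 `COc1ccc(N(C)c2nc(C)nc3ccccc23)cc1C(=O)OCCCCC[Se]C#N`: 714 nM
compound 2 `COc1ccc(N(C)c2nc(C)nc3ccccc23)cc1C(=O)OCC[Se]C#N`: 2960 nM
compound 3 `COc1ccc(N(C)c2nc(C)nc3ccccc23)cc1C(=O)OCCCCCC[Se]C#N`: 1050 nM

Compound 2 stands highest of the three: a 2.8-fold lower number from compound 2 to compound 3 (0.45 log units; beyond the scatter) and a 4.1-fold higher number from compound 1 to compound 2 (0.62 log units; beyond the scatter) both lie beyond the scatter, whereas a 1.5-fold higher number from compound 1 to compound 3 (0.17 log units; within the scatter) does not. Compound 4 `COc1ccc(N(C)c2nc(C)nc3ccccc23)cc1[Se]C` is not yet measured. Against compound 2 the change is a group of 2 heavy atoms (1 carbon, 1 selenium; no ring) in place of a group of 8 heavy atoms (4 carbon, 1 nitrogen, 2 oxygen, 1 selenium; no ring), on an aromatic carbon. The measured steps only alter the length of the chain carrying the selenocyanate; none removes the ester or puts selenium on the aromatic ring, so they bear on this step only loosely. Since those chain-length steps remained modest and the shared core is kept, a step of comparable size, a 1.0-fold higher number from compound 2 to compound 4 (0.01 log units; within the scatter), is expected, with wide uncertainty in either direction. Compound 4 is therefore expected to give about 3000 nM, between 700 nM and 13000 nM.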

Compound 4, half-maximal inhibitory concentration: 3 nM
Compound 4: middle estimate off by 1000-fold (3.00 log units), on the high side; measured number outside the range, below it.
By their numbers in this assay, from the lowest: compound 4; then compounds 1 and 3 (each within the scatter of the next); then compound 2.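

At this aromatic carbon, ortho to a methoxy group, the change in this assay gives a 990-fold lower number from compound 2 to compound 4 (2.99 log units; beyond the scatter), a step far larger than any seen on varying the chain length. A low number therefore needs neither the carbonyl nor the nitrile, both of which leave with the group of 8 heavy atoms. Nothing available explains the size of this step.

Open, on these data alone, is whether selenium is needed, as against a methylthio group or a plain methyl on this carbon. Also open, as far as these compounds go, is whether an ethyl group on selenium keeps the low number, and which part of the departing group accounts for the step, since the ester and the chain leave together.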